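The compounds below may be only part of what the source reports. "The series", "measured", "known", "first", "only" and "open" are said of these compounds alone.

Measured so far in a functional assay on MCF7 cells (Homo sapiens) for inhibition, read by MTT assay, with a stated time of 24 h; on this read-out lower numbers stand for stronger inhibition and higher numbers for weaker inhibition:
- compound 1, `CCOC(=O)C1=Cc2ccccc2OC1(OCc1cn(CC(=O)Nc2cccc(Cl)c2)nn1)C(F)(F)F`: 11600 nM
- compound 2, `CCOC(=O)C1=Cc2ccccc2OC1(OCc1cn(-c2ccccc2)nn1)C(F)(F)F`: > 150000 nM

For compound 2 the assay reports only a limit, (the limit of > 150000 nM in this assay, at which 1 of the 2 values shown sits), and no number. Compound 2 thus stands at the weak end of the two values shown, since its step from compound 1 is beyond the scatter. Compound 3, `CCOC(=O)C1=Cc2ccccc2OC1(OCc1cn(CC(=O)Nc2ccccc2Br)nn1)C(F)(F)F`, carries ((2-bromophenyl)carbamoyl)methyl in place of phenyl on an aromatic nitrogen. Among the measured compounds shown here, the one measured step that bears on this change is an at least 12-fold higher number from compound 1 to compound 2 (1.11 log units; beyond the scatter), which runs the opposite way, from a ((3-chlorophenyl)carbamoyl)methyl group to phenyl. For the measured compounds named here, compound 3 differs from compound 1 only in the halogen on that phenyl, and no measured step covers such a swap. Expected, therefore, is a large fall in the number, back toward compound 1: an at least 10-fold lower number from compound 2 to compound 3 (1.00 log units; beyond the scatter). For compound 3 the estimate is 15000 nM, with a range from 4000 nM to 60000 nM.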

Compound 3, half-maximal inhibitory concentration: > 150000 nM
Compound 3: a limit, no number; the forecaster's own chance of this, stated with the estimate: 15%; middle value at least 10-fold (1.00 log units) away from the limit.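

In this assay compound 3 gives > 150000 nM, which is a limit and not a number. Placing 2-bromophenyl in place of 3-chlorophenyl on the amide-type nitrogen gives an at least 12-fold higher number from compound 1 to compound 3 (1.11 log units; beyond the scatter), so the carbamoylmethyl chain on the aromatic nitrogen does not by itself secure a measurable value, and the group on the amide-type nitrogen also counts. The step from compound 2 to compound 3 cannot be read because both compounds sit at the same limit: the limit of > 150000 nM in this assay, at which 2 of the 3 values shown sit.

Compound 1 and compound 3 differ in both the halogen and its place on the phenyl, and the compounds shown do not separate the two. Also open, going by these compounds, is whether an amine or a carboxylic acid on that phenyl, in place of the halogen, would give a value clear of the limit.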